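Aryl ketone variation in the hydroxamate series

A few compounds are considered here, and "the series" means these few. Any claim that something is new, unique, unknown or untested is made for them only; others in the source may bear on it.

Compound 1 `Cn1cc(/C=C/C(=O)c2ccc(Cl)cc2)cc1/C=C/C(=O)NO` gives 29400 nM in an assay on isolated protein for inhibition of histone deacetylase HD1B (Zea mays) (on this read-out lower numbers stand for stronger inhibition and higher numbers for weaker inhibition), the higher of the two numbers recorded so far, while compound 2 `Cn1cc(/C=C/C(=O)c2ccc3ccccc3c2)cc1/C=C/C(=O)NO` gives 1800 nM in this assay, a gap beyond the scatter. Compound 3 `Cn1cc(/C=C/C(=O)c2ccsc2)cc1/C=C/C(=O)NO` carries thiophen-3-yl in place of 4-chlorophenyl on a carbonyl carbon. Within the data shown here, no measured pair shows this change, so its direction is open; the two values recorded say only that compound 2 sits far lower than compound 1. The step from compound 1 to compound 3 is expected to be small, a 1.5-fold lower number from compound 1 to compound 3 (0.17 log units; within the scatter), within or close to the scatter. Compound 3 is therefore estimated at 20000 nM, with a range of 5000 nM to 60000 nM.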

Compound 3, half-maximal inhibitory concentration: 22600 nM
Compound 3: middle estimate off by 1.1-fold (0.05 log units), on the low side, and the stated range covers the measured number.
By their numbers in this assay, from the lowest: compound 2; then compounds 3 and 1 (each within the scatter of the next).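

In this assay, thiophen-3-yl in place of 4-chlorophenyl gives a 1.3-fold lower number from compound 1 to compound 3 (0.11 log units; within the scatter), so at this position a five-membered aromatic ring with one hetero atom reads the same as the six-membered carbon ring. This single step cannot separate the loss of chlorine from the change in ring size or the entry of sulfur. Nothing available bears on the reason for this result. Still open, from the compounds shown here alone, is how a carboxylic acid or an amine on the aromatic ring would read, and whether pyridin-3-yl on the carbonyl carbon would match thiophen-3-yl.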